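A few compounds are considered here, and "the series" means these few. Any claim that something is new, unique, unknown or untested is made for them only; others in the source may bear on it.

Compound 3 `CC(C)=CCC1Cc2c(OC(=O)Nc3ccc(F)cc3)cc(=O)n(CCCO)c2CC1(C)C` sits level with compound 2 `COc1ccc(NC(=O)Oc2cc(=O)n(CCCO)c3c2CC(CC=C(C)C)C(C)(C)C3)cc1`, the two together being the lowest of the three numbers in a functional assay on PANC-1 cells (Homo sapiens) for inhibition, read by MTT assay, with a stated time of 24 h, tested at 10 uM (on this read-out lower numbers stand for less inhibition and higher numbers for more inhibition at the one concentration tested (going by the name of the read-out)), where compound 3 gives 0% and compound 2 gives 0%; compound 1 `CC(C)=CCC1Cc2c(OCc3ccccc3)cc(=O)n(CCCO)c2CC1(C)C` stands furthest away at 11.1%. Compound 4 `CC(C)=CCC1Cc2c(OC(=O)Nc3cccc(F)c3)cc(=O)n(CCCO)c2CC1(C)C` differs from compound 3 by 3-fluorophenyl in place of 4-fluorophenyl on an amide-type nitrogen. Among the compounds with values here, the steps that bear on it are a number 11.1 percentage points lower from compound 1 to compound 3 (beyond the scatter) and, closer in kind, no change at the digits printed from compound 2 to compound 3 (within the scatter), which shows that swapping a substituent on that phenyl ring left the read-out where it was. From this the expected step is a number 2 percentage points higher from compound 3 to compound 4 (within the scatter), none beyond the scatter. Compound 4 is therefore estimated at 2%, within a range of 0% to 12%.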

Compound 4, a percentage reported as inhibition, at one concentration (the size of the read-out at that concentration, not a potency): 0%
Estimate against measurement, compound 4: 2 percentage points above; measured number inside the range.
By their numbers in this assay, from the lowest: compounds 2, 3 and 4 (each within the scatter of the next); then compound 1.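

In this assay, 3-fluorophenyl in place of 4-fluorophenyl on the amide-type nitrogen gives no change at the digits printed from compound 3 to compound 4 (within the scatter), so moving the fluoro on that ring, like the earlier swap of substituent, leaves the read-out unmoved. The same holds against the 4-methoxyphenyl group, with no change at the digits printed from compound 2 to compound 4 (within the scatter) for that exchange. (3-Fluorophenyl)carbamoyl in place of benzyl on the oxygen gives a number 11.1 percentage points lower from compound 1 to compound 4 (beyond the scatter), making this the third carbamoyl group to stand at that level.

Going by these compounds, whether an amine or a carboxylic acid on that phenyl ring would lift the number remains open. Nothing available here accounts for these readings.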